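This account rests on a few compounds, and the source may have more. Where it says the series, first, only, none or still open, it means among the compounds named here.

Measured so far:
compound 1 `O=C(O)c1cncc(C2CC2c2ccc(OCc3c(-c4c(Cl)cccc4Cl)noc3C3CC3)cc2Cl)c1` — 103%
compound 2 `O=C(O)c1ccc([C@H]2C[C@](O)(c3ccc(OCc4c(-c5c(Cl)cccc5Cl)noc4C4CC4)cc3Cl)C2)cc1` — 105%

Both measured compounds were read in an assay on isolated protein for agonist activity at Bile acid receptor (Homo sapiens), read by FRET; a higher number here means a larger maximal response, a lower number a smaller maximal response. Compound 1 gives 103% and compound 2 gives 105%, so the two numbers lie within the scatter of each other and no order between them can be stated; compound 1 simply has the lower of the two numbers. Both reach roughly the full response of the reference.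

Compound 3 `CC(C)n1nc(C(=O)O)cc1C1CC1c1ccc(OCc2c(-c3c(Cl)cccc3Cl)noc2C2CC2)cc1Cl` has not been measured. It differs from compound 1 in one place: 3-carboxy-1-isopropyl-1H-pyrazol-5-yl in place of 5-carboxypyridin-3-yl on a saturated ring carbon. For the measured compounds named here, no step between measured compounds covers a change of this kind, so the expectation rests only on the two numbers above, which both sit at the level of the reference. The acid is kept, only the ring that carries it is exchanged. A step of about none beyond the scatter is expected, with the risk lying toward a lower maximal response rather than a higher one. Compound 3 is therefore expected to give 95% in this assay, with a range of 70% to 115%; the expected step is a number 8 percentage points lower from compound 1 to compound 3 (within the scatter).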

Compound 3, largest response reached (reported as efficacy), in percent of the reference or control that the assay uses in the Bile acid receptor assay: 102%
Compound 3: middle estimate off by 7 percentage points, on the low side; the range from low to high includes it.
By their numbers in the Bile acid receptor assay, from the lowest: compounds 3, 1 and 2 (each within the scatter of the next).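

In the Bile acid receptor assay the step is a number 1 percentage points lower from compound 1 to compound 3 (within the scatter), so at this saturated ring carbon the 5-carboxypyridin-3-yl can be exchanged for 3-carboxy-1-isopropyl-1H-pyrazol-5-yl, a larger group with a five-membered aromatic ring, with no readable change in maximal response. In a physicochemical assay for solubility (on this read-out lower numbers stand for lower solubility and higher numbers for higher solubility), compound 1 gives 165000 nM and compound 3 gives 158000 nM, two values within the scatter of each other, so the exchange leaves this read-out without a readable change as well. Nothing available accounts for this tolerance of the ring exchange.

From the compounds shown here alone, both groups compared here carry a carboxylic acid, so the outcome with an amide or an amine in its place remains open. Going by these compounds, the part played by the isopropyl also remains open, as does whether a methyl or a hydrogen on that pyrazole nitrogen would serve equally.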